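From methylsulfanyl to ethylsulfanyl on compound 3

This account rests on a few compounds, and the source may have more. Where it says the series, first, only, none or still open, it means among the compounds named here.

Values in a functional assay on HL-60 cells (Homo sapiens) for inhibition, read by resazurin assay, with a stated time of 72 h; on this read-out lower numbers stand for stronger inhibition and higher numbers for weaker inhibition:
- compound 1 `COc1cc(N2C(=O)CC2c2ccc(SC)cc2)cc(OC)c1OC`: 69 nM
- compound 2 `CCOc1ccc(C2C(C3CC3)C(=O)N2c2cc(OC)c(OC)c(OC)c2)cc1`: 201 nM
- compound 3 `C=CC1C(=O)N(c2cc(OC)c(OC)c(OC)c2)C1c1ccc(SC)cc1`: 61 nM

Compound 3 at 61 nM sits at the low end of these numbers, within the scatter of compound 1, while compound 2 lies beyond the scatter from it on the higher side. The next member is compound 4 `C=CC1C(=O)N(c2cc(OC)c(OC)c(OC)c2)C1c1ccc(SCC)cc1`, with methyl in place of hydrogen on a saturated chain carbon bound to a sulfur, which turns methylsulfanyl into ethylsulfanyl.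

Going by the values given here, no measured step touches this place. The only one available, a 1.1-fold lower number from compound 1 to compound 3 (0.05 log units; within the scatter), is vinyl in place of hydrogen on a saturated ring carbon, so it bears on the change only loosely, as a small addition elsewhere that stayed within the scatter. Compound 2 at 201 nM carries ethoxy and cyclopropyl groups, so it differs from compound 3 in more than one place and gives only a weak hint toward higher numbers for a longer chain.

In this assay a step within the scatter is therefore expected, leaning slightly toward a higher number. The expected step is a 1.5-fold higher number from compound 3 to compound 4 (0.17 log units; within the scatter). For compound 4 the estimate is 90 nM, with an expected range of 40 nM to 200 nM.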

Compound 4, half-maximal inhibitory concentration: 320 nM
The estimate for compound 4 lay 3.6-fold (0.55 log units) below the measured number, outside the stated range (above it).
By their numbers in this assay, from the lowest: compounds 3 and 1 (each within the scatter of the next); then compounds 2 and 4 (each within the scatter of the next).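

In this assay, extending methylsulfanyl to ethylsulfanyl on the vinyl-bearing core gives a step beyond the scatter (a 5.2-fold higher number from compound 3 to compound 4 (0.72 log units; beyond the scatter)), so a methyl of 1 heavy atom on this saturated chain carbon bound to a sulfur is enough to give a clear loss of inhibition. Going by these compounds alone, the only earlier step between compounds differing in one place, vinyl in place of hydrogen on a saturated ring carbon, stayed within the scatter (a 1.1-fold lower number from compound 1 to compound 3 (0.05 log units; within the scatter)), so the two places differ in how far the number moves, a contrast that rests on one step at each place. Nothing shown accounts for this difference or for the size of the new step.

From the compounds shown here alone, whether a longer chain such as propylsulfanyl, or a branched one such as isopropylsulfanyl, raises the number further remains open, as does whether the loss comes with any addition to methylsulfanyl or is specific to ethyl. Also open, going by these compounds, is whether the same change gives a step of similar size on the core of compound 1, which carries hydrogen in place of vinyl.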